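The compounds below may be only part of what the source reports. "The series", "measured", "known", "first", "only" and "open" are said of these compounds alone.

Measured in a functional assay on MT4 cells (Homo sapiens) for cytotoxicity; on this read-out higher numbers stand for weaker inhibition and lower numbers for stronger inhibition:
- compound 1 `COc1cc([S+]([O-])c2cccc(N)c2C#N)cc(C(F)(F)F)c1`: 108000 nM
- compound 2 `Cc1cc(O)cc(S(=O)(=O)c2cccc(N)c2C#N)c1`: 167000 nM

Compound 2, at 167000 nM, holds the higher of the two numbers, but the gap to compound 1 at 108000 nM lies within the scatter, so the two count as level. Both compounds sit at the weak end of what has been seen in this small set, and no order is drawn between them.

Compound 3 `Cc1cc(Br)cc(S(=O)(=O)c2cccc(N)c2C#N)c1` follows from compound 2 by one change, bromo in place of hydroxy on an aromatic carbon. Among the measured compounds shown here, no measured pair differs in one place only, so the data give no direct guide to the size of this step. A modest move toward a lower number is expected, a 2.4-fold lower number from compound 2 to compound 3 (0.38 log units; beyond the scatter), though a result within the scatter would not be surprising. For compound 3 the estimate is 70000 nM, with an expected range of 20000 nM to 200000 nM.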

Compound 3, half-maximal inhibitory concentration: 133000 nM
Compound 3: middle estimate off by 1.9-fold (0.28 log units), on the low side; the measured number falls inside the stated range.
By their numbers in this assay, from the lowest: compounds 1, 3 and 2 (each within the scatter of the next).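

In this assay the exchange of hydroxy for bromo on this aromatic carbon, meta to a large group and meta to a methyl group, gives a 1.3-fold lower number from compound 2 to compound 3 (0.10 log units; within the scatter) and so leaves compound 2 and compound 3 level. Among the compounds shown here, this is the first single-place comparison, and it shows that losing the hydrogen-bond donor and acceptor counted for hydroxy brings no readable change at this position. Nothing on hand accounts for this result.

On these data alone, whether an amine or a carboxylic acid at this position would move the number beyond the scatter remains open. As far as these compounds go, a longer chain in place of the methyl group also remains untested against the same core, so the tolerance seen here rests on one pair.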